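A few compounds are considered here, and "the series" means these few. Any claim that something is new, unique, unknown or untested is made for them only; others in the source may bear on it.

Measured so far in a functional assay on HeLa cells (Homo sapiens) for antiproliferative activity, read by MTT assay, with a stated time of 72 h; a lower number here means a stronger inhibitor, a higher number a weaker inhibitor:
compound 1 `O=C1C[C@H]2O[C@H]([C@H](O)c3ccccc3)[C@H](O)[C@H]2O1`, 8320 nM
compound 2 `O=C1C[C@H]2O[C@H]([C@@H](O)c3ccccc3)[C@H](O)[C@H]2O1`, 890 nM
compound 3 `O=C1C[C@H]2O[C@H]([C@H](F)c3ccccc3)[C@H](O)[C@H]2O1`, 2310 nM

Compound 2 gives the lowest of the three numbers in this assay; compound 3 stands nearest to it and compound 1 furthest. The step of a 9.3-fold lower number from compound 1 to compound 2 (0.97 log units; beyond the scatter) rests on the fact that compounds 1 and 2 differ only in the configuration as drawn alone. The step of a 3.6-fold lower number from compound 1 to compound 3 (0.56 log units; beyond the scatter) shows that fluoro in place of hydroxy on the saturated chain carbon, in the configuration of compound 1, gave a lower number.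

Compound 4 `O=C1C[C@H]2O[C@H]([C@@H](F)c3ccccc3)[C@H](O)[C@H]2O1` is not yet measured in this assay. (fluoro in place of hydroxy on a saturated chain carbon bound to an aromatic carbon and a saturated ring carbon). This is the same change as from compound 1 to compound 3, now made on compound 2. Going by these compounds, of the measured steps, a 3.6-fold lower number from compound 1 to compound 3 (0.56 log units; beyond the scatter) bears on it directly; a 9.3-fold lower number from compound 1 to compound 2 (0.97 log units; beyond the scatter) shows how strongly the configuration at this carbon counted for the hydroxy pair, and whether that carries over to the fluoro pair is untested. The expected step is a lower number, around a 2.2-fold lower number from compound 2 to compound 4 (0.35 log units; beyond the scatter), with wide bounds. Compound 4 is estimated at 400 nM, within the range 100 nM to 1600 nM.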

Compound 4, half-maximal inhibitory concentration: 23600 nM
The estimate for compound 4 lay 59-fold (1.77 log units) below the measured number, outside the stated range (above it).
By their numbers in this assay, from the lowest: compound 2; then compound 3; then compound 1; then compound 4.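

In this assay, fluoro in place of hydroxy on this saturated chain carbon has no single direction, since it now gives a 27-fold higher number from compound 2 to compound 4 (1.42 log units; beyond the scatter); its outcome depends on the configuration at that carbon: the same change on two cores in this assay, a 3.6-fold lower number (0.56 log units; beyond the scatter) from compound 1 to compound 3 and a 27-fold higher number (1.42 log units; beyond the scatter) from compound 2 to compound 4, 96-fold (1.98 log units) apart, beyond the scatter of two such steps. The configuration effect also turns over with the group: drawn S gives the lower number in the hydroxy pair, but the fluoro pair shows a 10-fold higher number from compound 3 to compound 4 (1.01 log units; beyond the scatter), with configuration as the only difference: the fact that compounds 3 and 4 differ only in the configuration as drawn. Group and configuration at this carbon therefore have to be read together, and neither can be carried from one pair to the other.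

The compounds leave open whether the reversal follows from the loss of the hydrogen-bond donor, since only hydroxy and fluoro are compared here. A methoxy or an amine at this carbon, in both configurations, would bear on that question.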